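The source may report more compounds than this note shows. Statements on the series, on what has been measured and on what is new or still open speak of the compounds shown alone.

Measured so far:
- compound 1 `Cc1ccc(-c2cs/c(=N/NC(=O)CSc3nnnn3-c3ccccc3)n2-c2ccccc2)cc1`: a functional assay on C6 cells (Rattus norvegicus) for cytotoxicity, read by MTT assay, with a stated time of 24 h, tested at 100 ug/mL (on this read-out lower numbers stand for a stronger effect and higher numbers for a weaker effect at the one concentration tested), 28.5%
- compound 2 `Cc1ccc(-c2cs/c(=N/NC(=O)CSc3nnnn3C)n2-c2ccccc2)cc1`: 39.7%
- compound 3 `Cc1ccc(-c2cs/c(=N/NC(=O)CSc3nnc(C)s3)n2-c2ccccc2)cc1`: 31.5%

Compound 1 holds the lowest of the three numbers; the gap to compound 3 is a number 3 percentage points higher from compound 1 to compound 3 (within the scatter) and stays within the scatter, while a number 11.2 percentage points higher from compound 1 to compound 2 (beyond the scatter) goes beyond it. Compound 4 `N#Cc1ccc(-c2cs/c(=N/NC(=O)CSc3nnnn3-c3ccccc3)n2-c2ccccc2)cc1` is not yet measured. It differs from compound 1 by cyano in place of methyl on an aromatic carbon. Going by the values given here, neither measured step touches this part of the molecule: a number 11.2 percentage points higher from compound 1 to compound 2 (beyond the scatter), a number 3 percentage points higher from compound 1 to compound 3 (within the scatter) and a number 8.2 percentage points lower from compound 2 to compound 3 (within the scatter) all change the group on the sulfur or on the aromatic nitrogen, so there is no direct precedent for the change at the 4-methylphenyl. In the absence of a bearing step no movement beyond the scatter is expected. For compound 4 the expected value in this assay is 31%, within 18% to 46%, meaning an expected step of a number 2.5 percentage points higher from compound 1 to compound 4 (within the scatter).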

Compound 4, a percentage reported as activity, at one concentration (the size of the read-out at that concentration, not a potency): 59.8%
For compound 4 the middle estimate is 28.8 percentage points below the measured one; the whole stated range lies below it.
By their numbers in this assay, from the lowest: compounds 1, 3 and 2 (each within the scatter of the next, the first and the last beyond it); then compound 4.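

In this assay the 4-methylphenyl proves a sensitive place: 4-cyanophenyl gives a number 31.3 percentage points higher from compound 1 to compound 4 (beyond the scatter) and so a weaker effect at the one concentration tested. Going by these compounds alone, this is the largest step so far, larger than any change on the sulfur or the aromatic nitrogen. Nothing on hand explains the loss.

Open, going by these compounds, is whether the loss is specific to cyano or follows any replacement of methyl, which an unsubstituted phenyl, a 4-chlorophenyl or a 4-methoxyphenyl would help to settle. Also open, on these data alone, is whether cyano acts alike with the sulfur groups of compound 2 and compound 3.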